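Imine aryl swap: thiophene to trifluoromethylphenyl

A few compounds are considered here, and "the series" means these few. Any claim that something is new, unique, unknown or untested is made for them only; others in the source may bear on it.

Among the compounds with values here, compound 2 `CN1CCN(c2ccc(Nc3ncc(/N=C/c4cccs4)c(NC4CCCC4)n3)cc2)CC1` holds the only number given in a functional assay on HeLa cells (Homo sapiens) for antiproliferative activity, read by MTT assay; on this read-out lower numbers stand for stronger inhibition and higher numbers for weaker inhibition: compound 2 gives 25700 nM. Compound 1 `CN1CCN(c2ccc(Nc3ncc(/N=C/c4ccccc4)c(NC4CCCC4)n3)cc2)CC1` sits at a limit of this assay, > 100000 nM (the limit of > 100000 nM in this assay, at which 1 of the 2 values shown sits). Within the data shown here, the step of an at least 3.8-fold lower number from compound 1 to compound 2 (0.59 log units; beyond the scatter) is the one measured change. Compound 3 `CN1CCN(c2ccc(Nc3ncc(/N=C/c4ccc(C(F)(F)F)cc4)c(NC4CCCC4)n3)cc2)CC1` turns that step back toward a phenyl ring, now carrying trifluoromethyl: 4-(trifluoromethyl)phenyl in place of thiophen-2-yl on a carbon with a double bond to nitrogen. Because an at least 3.8-fold lower number from compound 1 to compound 2 (0.59 log units; beyond the scatter) went beyond the scatter in the favourable direction, the return to a six-membered carbon ring is expected to weaken inhibition in this assay, with a real chance of a limit. Compound 3 is expected at 80000 nM (range 20000 nM to 300000 nM), a step of a 3.1-fold higher number from compound 2 to compound 3 (0.49 log units; beyond the scatter).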

Compound 3, half-maximal inhibitory concentration: > 100000 nM
Compound 3 was reported as a limit (the forecaster's own chance of this, stated with the estimate: 45%); middle value at least 1.2-fold (0.09 log units) from the limit.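

With the change to 4-(trifluoromethyl)phenyl on a carbon with a double bond to nitrogen, this assay shows an at least 3.8-fold higher number from compound 2 to compound 3 (0.59 log units; beyond the scatter), so compound 2 remains the only one of the three with a readable number. Trifluoromethyl on the phenyl ring therefore does not recover what thiophen-2-yl gives here. The step between the two phenyl compounds cannot be read, since compound 1 and compound 3 are both limits: the limit of > 100000 nM in this assay, at which 2 of the 3 values shown sit.

As far as these compounds go, whether a furan-2-yl ring, or a thiophen-2-yl ring carrying an amine or a carboxylic acid, would hold or improve on compound 2 remains open.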